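The compounds below may be only part of what the source reports. "The series", "measured", "known", "first", "only" and "open" are said of these compounds alone.

Compound 1 `Nc1ccccc1NC(=O)c1ccc(CSc2ccccn2)cc1`: 1000 nM
Compound 2 `Nc1ccccc1NC(=O)c1ccc(CNc2ncccn2)cc1`: 2000 nM

Among the compounds with values here, in a functional assay on HCT-116 cells (Homo sapiens) for cytotoxicity, read by MTT assay (on this read-out lower numbers stand for stronger inhibition and higher numbers for weaker inhibition), compound 2 gives 2000 nM and cannot be told apart from compound 1, the only other compound measured. Compound 3 `COc1ccc(-c2ccnc(NCc3ccc(C(=O)Nc4ccccc4N)cc3)n2)cc1OC` is still unmeasured and differs from compound 2 by 3,4-dimethoxyphenyl in place of hydrogen on an aromatic carbon. Within the data shown here, the only measured step, a 2.0-fold higher number from compound 1 to compound 2 (0.30 log units; within the scatter), swaps a different group at a different place, so it offers only weak guidance for this change. Among the measured compounds shown here, no measured compound carries a group at this place, so the data give no direction. With so little to go on, a large step is not expected. The expected change is a 2.0-fold lower number from compound 2 to compound 3 (0.30 log units; within the scatter), which means no firm shift beyond the scatter. For compound 3 the estimated value is 1000 nM, with an expected range from 300 nM to 3000 nM.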

Compound 3, half-maximal inhibitory concentration: 100 nM
For compound 3 the middle estimate is 10-fold (1.00 log units) above the measured one, outside the stated range (below it).
By their numbers in this assay, from the lowest: compound 3; then compounds 1 and 2 (each within the scatter of the next).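

In this assay, 3,4-dimethoxyphenyl in place of hydrogen on an aromatic carbon gives a 20-fold lower number from compound 2 to compound 3 (1.30 log units; beyond the scatter), the first change shown that reaches beyond the scatter. The earlier pair, which differed at another place, did not show this, so the position next to the ring nitrogen emerges as one where a substituent can shift the read-out markedly. It accepts a group of 10 heavy atoms, with one six-membered aromatic ring of carbon only, and the number falls rather than rises. Nothing available accounts for this gain.

Going by these compounds, it remains open whether a plain phenyl ring, a phenyl ring with a single methoxy group, or a small group such as methyl would give a similar step. Also unsettled is whether 3,4-dimethoxyphenyl would act the same way on the (pyridin-2-yl)sulfanyl compound 1.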